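The source may hold more compounds than are shown below. What is called first, only, known or untested is meant among the compounds shown, and "the series" means these compounds.

Measured compounds in an assay on cell membranes for displacement of a labelled ligand from corticotropin-releasing factor receptor 1 (Rattus norvegicus); on this read-out higher numbers stand for weaker inhibition and lower numbers for stronger inhibition:
Compound 1 `CCCCN(CCC)c1nc(C)nc2c(-c3c(C)cc(N(C)C)nc3C)c(C)nn12` gives 12.8 nM.
Compound 2 `CCCCN(CCC)c1nc(C)nc2c(-c3ccc(OC)nc3C)c(C)nn12` gives 2.4 nM.
Compound 3 `CCCCC(C)Nc1nc(C)nc2c(-c3ccc(OC)nc3C)c(C)nn12` gives 5.1 nM.

Compound 1 stands with the highest number of the three; compound 3 lies nearest and compound 2 furthest, both gaps beyond the scatter. Compound 4 `CCN(CC)c1nc(C)nc2c(-c3c(C)cc(N(C)C)nc3C)c(C)nn12` differs from compound 1 in one place: diethylamino in place of butyl(propyl)amino on an aromatic carbon. Among the measured compounds shown here, the only measured step at this position is a 2.1-fold higher number from compound 2 to compound 3 (0.33 log units; beyond the scatter), which exchanged one amino group for another and raised the number modestly. For the measured compounds named here, no measured step replaces the group with shorter chains as here, so the direction is uncertain; a modest rise with a wide range seems the fairest expectation. Compound 4 is therefore expected to give 25 nM, between 8 nM and 80 nM. The expected step is a 2.0-fold higher number from compound 1 to compound 4 (0.29 log units; within the scatter).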

Compound 4, half-maximal inhibitory concentration: 58 nM
Beside the measured number, compound 4's estimate is 2.3-fold (0.37 log units) below it; the range from low to high includes it.
By their numbers in this assay, from the lowest: compound 2; then compound 3; then compound 1; then compound 4.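

Replacing butyl(propyl)amino with the smaller diethylamino on this aromatic carbon gives a 4.5-fold higher number from compound 1 to compound 4 (0.66 log units; beyond the scatter). Unlike the earlier step at this position, this change keeps both chains on the nitrogen and only shortens them, so on this core the number responds to chain length alone. Nothing measured here explains why the shorter chains give the weaker result.

As far as these compounds go, whether dibutylamino or morpholine would give a lower or higher number remains open. So does whether diethylamino would have a similar effect on compound 2.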